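The source may hold more compounds than are shown below. What is called first, only, known or untested is meant among the compounds shown, and "the series" means these compounds.

Measured so far: compound 1 `S=C(Nc1ccc(Cl)cc1)Nc1nc2ccccc2s1`, compound 2 `CCOc1ccc2nc(Nc3nc4ccc(F)cc4s3)sc2c1`, compound 3 `Fc1ccc2nc(NC(=S)Nc3ccc(Cl)cc3)sc2c1`.

In a functional assay on B16-F10 cells (Mus musculus) for cytotoxicity, read by MTT assay, with a stated time of 48 h (a lower number here means a stronger inhibitor, a higher number a weaker inhibitor), compound 2 gives 33200 nM and compound 3 gives 48100 nM. Compound 1 gives > 50000 nM, which is a limit of the assay and not a number. Within the data shown here, the only single-point change among the measured compounds is hydrogen in place of fluoro on an aromatic carbon, giving an at least 1.0-fold higher number from compound 3 to compound 1 (0.01 log units; that floor lies within the scatter), a floor that follows from the limit of > 50000 nM in this assay, at which 1 of the 3 values shown sits. The difference between the cores of compound 2 and compound 3 is not broken down here.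

Compound 4 `CCOc1ccc2nc(Nc3nc4ccccc4s3)sc2c1` is not yet measured. It differs from compound 2 by hydrogen in place of fluoro on an aromatic carbon, the same change as before. Resting on an at least 1.0-fold higher number from compound 3 to compound 1 (0.01 log units; that floor lies within the scatter), the expected step is a 1.2-fold higher number from compound 2 to compound 4 (0.08 log units; within the scatter), small and within the scatter. Compound 4 is accordingly expected to give 40000 nM, most likely between 25000 nM and 70000 nM.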

Compound 4, half-maximal inhibitory concentration: > 50000 nM
Compound 4 ended at the assay's limit; the forecaster's own chance of this, stated with the estimate: 35%; middle value at least 1.2-fold (0.09 log units) from the limit.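

In this assay, putting hydrogen in place of fluoro on an aromatic carbon gives an at least 1.5-fold higher number from compound 2 to compound 4 (0.17 log units; that floor lies within the scatter). The value of compound 4, > 50000 nM, is a limit of the assay and not a number. The change therefore appears on both cores only as a floor, so the data neither show that its size carries from one core to the other nor show that it does not: the same change on two cores in this assay, an at least 1.0-fold higher number (0.01 log units; that floor lies within the scatter) from compound 3 to compound 1 and an at least 1.5-fold higher number (0.17 log units; that floor lies within the scatter) from compound 2 to compound 4; the limit leaves it open whether they differ

The compounds shown leave open how the series would read away from this limit: the limit of > 50000 nM in this assay, at which 2 of the 4 values shown sit. Whether an amine or a carboxylic acid in place of the fluoro would give a value clear of that limit also stays open.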